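This account rests on a few compounds, and the source may have more. Where it says the series, first, only, none or still open, it means among the compounds named here.

Of the compounds shown here, three built on one shared core have been measured for their ability to kill stomach cancer cells. Compound 1 `NNC(=O)CSc1nnc(-c2ccncc2)o1` carries only a free hydrazide end; in a functional assay on BGC-823 cells (Homo sapiens) for cytotoxicity, read by MTT assay, with a stated time of 48 h (on this read-out higher numbers stand for weaker inhibition and lower numbers for stronger inhibition), compound 1 gives 3260 nM. Compound 2 `O=C(CSc1nnc(-c2ccncc2)o1)N/N=C/c1cccc(C(F)(F)F)c1` extends that end with a trifluoromethyl-bearing aromatic ring, and in this assay compound 2 gives 13000 nM. Compound 3 `COc1cccc(/C=N/NC(=O)CSc2nnc(-c3ccncc3)o2)c1` swaps that trifluoromethyl for a methoxy group, and in this assay compound 3 gives 15800 nM, the highest of the three numbers: the step here is a 1.2-fold higher number from compound 2 to compound 3 (0.08 log units; within the scatter), while compound 1 sits clearly lower.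

Compound 4 `COc1cc(/C=N/NC(=O)CSc2nnc(-c3ccncc3)o2)ccc1O` differs from compound 3 by hydroxy in place of hydrogen on an aromatic carbon. Going by the values given here, the only measured step of a comparable kind, a swap of one aromatic substituent for another, was a 1.2-fold higher number from compound 2 to compound 3 (0.08 log units; within the scatter). Among the compounds with values here, no measured step adds a hydroxy group, so the guidance is thin. In this assay compound 4 is therefore expected to stay close to compound 3, a step of a 1.1-fold lower number from compound 3 to compound 4 (0.02 log units; within the scatter), with an estimated value of 15000 nM within a range from 6000 nM to 40000 nM.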

Compound 4, half-maximal inhibitory concentration: 4320 nM
The estimate for compound 4 lay 3.5-fold (0.54 log units) above the measured number, outside the stated range (below it).
By their numbers in this assay, from the lowest: compounds 1 and 4 (each within the scatter of the next); then compounds 2 and 3 (each within the scatter of the next).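

Placing a hydroxy group on the ring, so that 3-methoxyphenyl becomes 4-hydroxy-3-methoxyphenyl, gives in this assay a step of a 3.7-fold lower number from compound 3 to compound 4 (0.56 log units; beyond the scatter), which means stronger inhibition of these cells. Going by these compounds alone, the earlier change on this ring, a 1.2-fold higher number from compound 2 to compound 3 (0.08 log units; within the scatter), showed no real effect, so this is the first sign that a change on the aromatic ring can move the number beyond the scatter, here at the carbon ortho to a methoxy group and para to a large group. Nothing available here gives a reason for this step.

As far as these compounds go, whether the step depends on the methoxy group remains open, as does whether the hydroxy hydrogen matters. An amine, a fluorine or a second methoxy at this same carbon could show how specific the effect of hydroxy is.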